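Naphthalene ring in place of 4-methoxyphenyl on a urea

The compounds below may be only part of what the source reports. "The series", "measured", "known", "first", "only" and "open" are said of these compounds alone.

Compounds measured so far in an assay on isolated protein for inhibition of proto-oncogene tyrosine-protein kinase receptor Ret variant V804M (Homo sapiens), read by 33P incorporation, with stated times of 15 min and 40 min; a higher number here means a weaker inhibitor, a lower number a stronger inhibitor:
compound 1, `O=C(Nc1ccc(Nc2ncnc3c2OCCN3)cc1)Nc1ccc(Cl)c(C(F)(F)F)c1`, 188 nM
compound 2, `COc1ccc(NC(=O)Nc2ccc(Nc3ncnc4c3OCCN4)cc2)cc1`, 824 nM
compound 3, `COc1cccc(NC(=O)Nc2ccc(Nc3ncnc4c3OCCN4)cc2)c1`, 5290 nM

Compound 2 stands second highest of the three numbers. Among the measured compounds shown here, compound 1 gives a lower number than compound 2, and compound 3 a higher one; the step of a 6.4-fold higher number from compound 2 to compound 3 (0.81 log units; beyond the scatter) is the only change measured in one place, and it shows that moving the methoxy group from 4-methoxyphenyl to 3-methoxyphenyl weakens inhibition in this assay beyond the scatter.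

Compound 4, `O=C(Nc1ccc(Nc2ncnc3c2OCCN3)cc1)Nc1cccc2ccccc12`, is not yet measured. It differs from compound 2 as follows: naphthalen-1-yl in place of 4-methoxyphenyl on an amide-type nitrogen. For the measured compounds named here, the change removes the only acceptor of that group and adds a second six-membered aromatic ring of carbon only, on the amide-type nitrogen next to the carbonyl carbon.

Going by the values given here, no measured step puts a second ring on that nitrogen. The step from compound 2 to compound 3 shows that this part of the molecule matters, and the pair of compound 1 and compound 2 shows that a group without a methoxy can give a lower number. Among the compounds with values here, because of a 6.4-fold higher number from compound 2 to compound 3 (0.81 log units; beyond the scatter) a step of several multiples in either direction seems possible; the expectation is therefore a small or no step, a 1.4-fold lower number from compound 2 to compound 4 (0.14 log units; within the scatter), with wide uncertainty.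

Compound 4 is estimated at 600 nM, ranging from 120 nM to 3000 nM.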

Compound 4, half-maximal inhibitory concentration: > 10000 nM
Compound 4: no number, only a limit; the forecaster's own chance of this, stated with the estimate: 5%; middle value at least 16-fold (1.22 log units) away from the limit.
By their numbers in this assay, from the lowest: compound 1; then compound 2; then compound 3. At a limit, above all of these: compound 4.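

In this assay, compound 4 gives only a limit of the assay, not a number: the limit of > 10000 nM in this assay, at which 1 of the 4 values shown sits.

Placing naphthalen-1-yl in place of 4-methoxyphenyl on the amide-type nitrogen gives an at least 12-fold higher number from compound 2 to compound 4 (1.08 log units; beyond the scatter), so the earlier compounds' range of aryl groups on this nitrogen does not extend to every aromatic group, and this change goes with a large loss of inhibition rather than the small step that compound 1 and compound 2 might have suggested. Measured against the other methoxy compound, the same change gives an at least 1.8-fold higher number from compound 3 to compound 4 (0.27 log units; that floor lies within the scatter), and this floor alone does not set the two compounds clearly apart, although the true gap could be larger.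

This single change removes the methoxy group and adds a second ring together, so the compounds shown cannot tell which of these two differences goes with the loss, and they give no cause for it. From the compounds shown here alone, it also remains open how an unsubstituted phenyl group or a naphthalen-2-yl group on the same nitrogen would read, which could help separate the effect of the added ring from that of the lost methoxy group.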